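The compounds below may be only part of what the source reports. "The series", "measured", "known", "first", "only" and "open" are said of these compounds alone.

In an ADME assay on CHO cells (Cricetulus griseus) for cytotoxicity, read by LDH release (a lower number here means a stronger inhibitor, a higher number a weaker inhibitor), compound 1 `CC(Oc1ccc(Cl)cc1Cl)C(=O)NC(C)c1ccc(F)cc1` is the starting point. Compound 1 reaches only a limit of the assay, > 100000 nM. Its form with a defined configuration, compound 2 `CC(Oc1ccc(Cl)cc1Cl)C(=O)N[C@H](C)c1ccc(F)cc1`, gives 97000 nM. Among the measured compounds shown here, the one measured step, an at least 1.0-fold lower number from compound 1 to compound 2 (0.01 log units; that floor lies within the scatter), reflects only the fact that one of compounds 1 and 2 is drawn with a defined configuration and the other without, at the place where they differ and says nothing about changing a group. Compound 3 `CC(Oc1ccc(Cl)cc1Cl)C(=O)NC1(c2ccc(F)cc2)CC1` gives 28000 nM, a lower number than that of compound 2. Compound 4 `CC(Oc1ccc(Cl)cc1Cl)C(=O)NC(c1ccc(F)cc1)C1CCC1` remains unmeasured and differs from compound 1 thus: cyclobutyl in place of methyl on a saturated chain carbon bound to an amide-type nitrogen and an aromatic carbon. For the measured compounds named here, no measured step covers this change, so the only guide is compound 3 at 28000 nM, which points modestly towards a lower number. The expected size and direction are an at least 2.8-fold lower number from compound 1 to compound 4 (0.45 log units; beyond the scatter). For compound 4 the estimate is 35000 nM, with an expected range of 12000 nM to 100000 nM.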

Compound 4, half-maximal inhibitory concentration: > 100000 nM
Compound 4: no number, only a limit (the forecaster's own chance of this, stated with the estimate: 15%); at least 2.8-fold (0.45 log units) between middle value and limit.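

The step between compound 1 and compound 4 cannot be read, because both stand at the same limit: the limit of > 100000 nM in this assay, at which 2 of the 4 values shown sit. The compounds shown leave open whether cyclobutyl in place of methyl changes the number in this assay at all.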